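The compounds below may be only part of what the source reports. "The series", "measured", "known", "first", "only" and "open" are said of these compounds alone.

Compound 1 `CCOC(=O)C(C)Nc1cccc2c(S(=O)(=O)Nc3onc(C)c3C)cccc12` gives 400 nM in an assay on VSM-A10 cells for antagonist activity at Endothelin-1 receptor (Rattus norvegicus); on this read-out higher numbers stand for weaker inhibition and lower numbers for stronger inhibition.
Compound 2 `Cc1noc(NS(=O)(=O)c2cccc3c(NC(=O)C(C)C)cccc23)c1C` gives 880 nM in this assay.
Compound 3 `Cc1noc(NS(=O)(=O)c2cccc3c(N4CCCC4=O)cccc23)c1C` gives 130 nM in this assay.

Compound 3 stands lowest of the three: the steps of a 3.1-fold lower number from compound 1 to compound 3 (0.49 log units; beyond the scatter) and a 6.8-fold lower number from compound 2 to compound 3 (0.83 log units; beyond the scatter) both lead down to it. Compound 4 `Cc1noc(NS(=O)(=O)c2cccc3ccccc23)c1C` differs from compound 3 by hydrogen in place of 2-oxopyrrolidin-1-yl on an aromatic carbon. For the measured compounds named here, no measured step removes the group at this place altogether; the two steps onto compound 3 only swap one group for 2-oxopyrrolidin-1-yl, so they bear on the change loosely. Since compounds 1 and 2, each carrying a different group there, both show higher numbers than compound 3, losing the group is expected to raise the number, by about a 9.2-fold higher number from compound 3 to compound 4 (0.97 log units; beyond the scatter). Compound 4 is therefore estimated at 1200 nM, within 250 nM to 6000 nM.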

Compound 4, half-maximal inhibitory concentration: 20000 nM
Compound 4: middle estimate off by 17-fold (1.22 log units), on the low side; measured number above the stated range.
By their numbers in this assay, from the lowest: compound 3; then compound 1; then compound 2; then compound 4.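

With only hydrogen on this aromatic carbon, the number climbs steeply: a 150-fold higher number from compound 3 to compound 4 (2.19 log units; beyond the scatter), alongside a 23-fold higher number from compound 2 to compound 4 (1.36 log units; beyond the scatter) and a 50-fold higher number from compound 1 to compound 4 (1.70 log units; beyond the scatter). Among these four compounds, having any of the three groups here matters far more than which one it is, since the steps among compounds 1, 2 and 3 are only modest. Nothing available explains why losing the group costs so much. From the compounds shown here alone, it remains open whether a small group, such as a plain amine or a methyl, would already restore the lower numbers, or whether a larger group like 2-oxopyrrolidin-1-yl is needed.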